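The compounds below may be only part of what the source reports. "The series", "measured", "known", "first", "only" and "open" are said of these compounds alone.

In a functional assay on PC-3 cells (Homo sapiens) for cytotoxicity, read by MTT assay, with a stated time of 72 h (a lower number here means a stronger inhibitor, a higher number a weaker inhibitor), compound 1 `CCCC(Nc1cncc(-c2ccc(O)c(OC)c2)n1)c1ccc(OC)cc1` gives 3000 nM. Among the measured compounds shown here, this is the only number available, so it can't yet be ranked as strong or weak against close relatives. Compound 2 `CCCC(Nc1cncc(-c2ccc(O)c(OC)c2)n1)c1ccc(F)cc1`, which has the same shared core, stands in this assay as "not determined" (no result reported) and offers no comparison.

The next compound to be tested is compound 3 `CCCC(Nc1cncc(-c2ccc(O)c(OC)c2)n1)c1cccnc1`. It keeps the core of compound 1 and changes one group: pyridin-3-yl in place of 4-methoxyphenyl on a saturated chain carbon bound to a nitrogen on an aromatic ring and a saturated chain carbon. In words, pyridin-3-yl takes the place of 4-methoxyphenyl on a saturated chain carbon bound to a nitrogen on an aromatic ring and a saturated chain carbon.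

For the measured compounds named here, no measured pair shows how this assay responds to a change at this place, so any forecast is uncertain and rests on a single value and the structural change. A modest loss of inhibition seems the most likely outcome, although a result within the usual scatter would be no surprise. The expected shift is a 2.0-fold higher number from compound 1 to compound 3 (0.30 log units; within the scatter), towards a higher number. For compound 3, the estimated value is 6000 nM, with an expected range from 1800 nM to 20000 nM.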

Compound 3, half-maximal inhibitory concentration: 300 nM
Beside the measured number, compound 3's estimate is 20-fold (1.30 log units) above it; measured number outside the range, below it.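

In this assay, among the compounds shown here, the first measured step at this position is a 10-fold lower number from compound 1 to compound 3 (1.00 log units; beyond the scatter) and it shows that the group carried on this saturated chain carbon has a clear influence on the read-out. The 4-methoxyphenyl group is also not required for activity against these cells: pyridin-3-yl, which has fewer heavy atoms and a nitrogen in its aromatic ring, gives the stronger inhibitor of this pair. No supporting measurement explains the difference, so the reason for this gain remains unknown.

This single pair changes two things at once, since the methoxy group leaves and a ring nitrogen enters, so it cannot show which of the two matters more for the result. A plain phenyl group at this place would separate those two parts of the change, while pyridin-4-yl or pyridin-2-yl would test whether the location of the ring nitrogen matters.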